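Propargyl to benzyl on the aromatic-ring nitrogen

A few compounds are considered here, and "the series" means these few. Any claim that something is new, unique, unknown or untested is made for them only; others in the source may bear on it.

Two members of the series have numbers in an assay on CHO cells for displacement of a labelled ligand from adenosine receptor A1 (Homo sapiens), read by scintillation counting, with a stated time of 1 h, tested at 1 uM; on this read-out lower numbers stand for less inhibition and higher numbers for more inhibition at the one concentration tested (going by the name of the read-out). Compound 1 `O=C(Nc1ncc(-c2cccc(Cl)c2)c(-c2ccccc2)n1)C1CCCC1` gives 47%, while compound 2 `C#CCNc1ncc(-c2cccc(Cl)c2)c(-c2ccccc2)n1` gives 76%. Within the data shown here, compound 2 stands highest of the two; its only neighbour is compound 1, and the one measured step, a number 29 percentage points higher from compound 1 to compound 2 (beyond the scatter), is modest and beyond the scatter. Compound 3 `Clc1cccc(-c2cnc(NCc3ccccc3)nc2-c2ccccc2)c1` differs from compound 2 by phenyl in place of ethynyl on a saturated chain carbon bound to a nitrogen on an aromatic ring, read one bond further out as propargyl to benzyl, propargylamino to benzylamino. Among the measured compounds shown here, no measured step covers this change: the single known step swaps cyclopentylcarbonyl for propargyl on the nitrogen, a different kind of exchange, so it gives little guidance on ethynyl against phenyl. With compound 2 and compound 3 both keeping the amine, a small shift in this assay is expected, direction uncertain. Compound 3 is expected to give 70%, within 45% to 90%. The expected step is a number 6 percentage points lower from compound 2 to compound 3 (within the scatter).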

Compound 3, a percentage reported as inhibition, at one concentration (the size of the read-out at that concentration, not a potency): 16%
The estimate for compound 3 lay 54 percentage points above the measured number; the whole stated range lies above it.
By their numbers in this assay, from the lowest: compound 3; then compound 1; then compound 2.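

In this assay, this position proves sensitive to what the saturated chain carbon carries: with phenyl in place of ethynyl, the step is a number 60 percentage points lower from compound 2 to compound 3 (beyond the scatter), although the nitrogen on the aromatic ring stays an amine. Benzyl also compares poorly with cyclopentylcarbonyl, with a number 31 percentage points lower from compound 1 to compound 3 (beyond the scatter), so the gain seen with propargyl does not extend to every group that leaves this nitrogen as an amine. Nothing measured on these compounds accounts for the difference between propargyl and benzyl.

On these data alone, it remains open whether the low number goes with the aromatic ring or with the larger count of heavy atoms, as phenyl differs from ethynyl in both. Cyclohexylmethyl, a propyl chain or an unsubstituted amine on the same nitrogen would help separate these readings.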